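The source may report more compounds than this note shows. Statements on the series, on what has been measured and on what is new or still open speak of the compounds shown alone.

In a functional assay on PC-3 cells (Homo sapiens) for cytotoxicity, read by MTT assay, with a stated time of 72 h (on this read-out lower numbers stand for stronger inhibition and higher numbers for weaker inhibition), compound 1 `COc1ccc(/C=C/c2cc(C)n[nH]2)cc1` gives 8900 nM and compound 3 `COc1ccc(/C=C/C(=O)CC(C)=O)cc1OC` gives 8900 nM, so compound 3 stands level with compound 1. Compound 2 `COc1ccc(/C=C/c2cc(C)no2)cc1OC` reads > 100000 nM, which is a limit of the assay and not a number. Compound 4 `COc1ccc(/C=C/c2cc(C)n[nH]2)cc1OC` carries 3-methyl-1H-pyrazol-5-yl in place of the (2-oxopropyl)carbonyl of compound 3, on a double-bonded chain carbon bound to a double-bonded chain carbon: 3-methyl-1H-pyrazol-5-yl in place of (2-oxopropyl)carbonyl on a double-bonded chain carbon bound to a double-bonded chain carbon. One measured step changes the group at this same place, and it is large: an at least 11-fold lower number from compound 2 to compound 3 (1.05 log units; beyond the scatter). A change here can therefore shift this assay strongly, which keeps the expected range wide. Compound 1, however, carries the same 3-methyl-1H-pyrazol-5-yl and gives 8900 nM, so no step beyond the scatter is expected. The estimated change is a 1.1-fold lower number from compound 3 to compound 4 (0.05 log units; within the scatter). Compound 4 is expected at 8000 nM, with an estimated range from 2500 nM to 30000 nM.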

Compound 4, half-maximal inhibitory concentration: 12600 nM
Beside the measured number, compound 4's estimate is 1.6-fold (0.20 log units) below it; the measured number falls inside the stated range.
By their numbers in this assay, from the lowest: compounds 1, 3 and 4 (each within the scatter of the next). At a limit, above all of these: compound 2.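

In this assay, the change at this place is a 1.4-fold higher number from compound 3 to compound 4 (0.15 log units; within the scatter), and the methoxy in place of hydrogen on an aromatic carbon is a 1.4-fold higher number from compound 1 to compound 4 (0.15 log units; within the scatter), so neither change moves the read-out beyond the scatter. The pair of compounds carrying the two 3-methyl heteroaromatic groups does separate, with an at least 7.9-fold lower number from compound 2 to compound 4 (0.89 log units; beyond the scatter), so 3-methyl-1,2-oxazol-5-yl now stands apart from both 3-methyl-1H-pyrazol-5-yl and (2-oxopropyl)carbonyl on this chain carbon. Compound 2 reads > 100000 nM, which is a limit and not a number, so the size of that step remains a bound: the limit of > 100000 nM in this assay, at which 1 of the 4 values shown sits.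

The compounds shown leave open whether a carboxylic acid or an amide on this chain carbon would read level with compound 3 and compound 4. They also leave open whether any group here would give a number beyond the scatter below theirs.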